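Cyclopropyl for Propargyl Amides in Mouse Toxicity

A few compounds are considered here, and "the series" means these few. Any claim that something is new, unique, unknown or untested is made for them only; others in the source may bear on it.

Compound 1, `C#CCNC(=O)/C(C)=C(\C)c1ccc(Br)cc1`: 180 mg/kg
Compound 2, `C/C(C(=O)NC1CC1)=C(/C)c1ccc(Br)cc1`: 100 mg/kg
Compound 3, `C#CCNC(=O)/C(C)=C(\C)c1ccccc1`: 150 mg/kg

These three values come from a toxicity assay on the whole organism (strain Icem-CET (SPF Caw)) for cytotoxicity, with Mus musculus as the target; a higher number here means that more compound is needed for the effect, a lower number that less compound is needed. Compound 2 differs from compound 1 by cyclopropyl in place of propargyl on an amide-type nitrogen, which gave a 1.8-fold lower number from compound 1 to compound 2 (0.26 log units; within the scatter). The two cores differ by hydrogen in place of bromo on an aromatic carbon, which gave a 1.2-fold lower number from compound 1 to compound 3 (0.08 log units; within the scatter). Compound 4, `C/C(C(=O)NC1CC1)=C(/C)c1ccccc1`, has not been measured. It differs from compound 3 by cyclopropyl in place of propargyl on an amide-type nitrogen, the same change as that made from compound 1 to compound 2, here on the core of compound 3. The earlier step of this change was a 1.8-fold lower number from compound 1 to compound 2 (0.26 log units; within the scatter). On that basis, for compound 4 a step of similar size is expected, a 1.8-fold lower number from compound 3 to compound 4 (0.25 log units; within the scatter). Compound 4 is therefore estimated at 85 mg/kg, with a likely range from 50 mg/kg to 150 mg/kg in this assay.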

Compound 4, dose for half-maximal effect: 100 mg/kg
The estimate for compound 4 lay 1.2-fold (0.07 log units) below the measured number; measured number inside the range.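

In this assay, cyclopropyl in place of propargyl on the amide-type nitrogen gave a 1.5-fold lower number from compound 3 to compound 4 (0.18 log units; within the scatter) on the core of compound 3, and the two steps of this change agree: the same change on two cores in this assay, a 1.8-fold lower number (0.26 log units; within the scatter) from compound 1 to compound 2 and a 1.5-fold lower number (0.18 log units; within the scatter) from compound 3 to compound 4, 1.2-fold (0.08 log units) apart, within the scatter of two such steps. With cyclopropyl held in place, hydrogen in place of bromo gave no change at the digits printed from compound 2 to compound 4 (within the scatter) and this also matches the earlier step: the same change on two cores in this assay, a 1.2-fold lower number (0.08 log units; within the scatter) from compound 1 to compound 3 and no change at the digits printed (within the scatter) from compound 2 to compound 4, 1.2-fold (0.08 log units) apart, within the scatter of two such steps. The change thus carried across these two cores without a detectable difference, but with every step within the scatter, this does not show that the change itself has any effect in this assay or that it would carry to other cores.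

The compounds shown leave open whether an amine or a longer chain on the amide-type nitrogen would give a step beyond the scatter. They also leave open how a carboxylic acid on the aromatic carbon would compare with bromo or hydrogen.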